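Sulfonamide Heteroaryl Exchange on a Shared Core

The compounds below may be only part of what the source reports. "The series", "measured", "known", "first", "only" and "open" are said of these compounds alone.

Compound 1, `C=C1CC[C@@H]2[C@](C)(COC(C)=O)[C@H](OC(C)=O)CC[C@@]2(C)[C@H]1CC(Nc1ccc(S(=O)(=O)Nc2nccs2)cc1)C1=CCOC1=O`, 8000 nM in a functional assay on HCT-116 cells (Homo sapiens) for inhibition, read by sulforhodamine B assay, with a stated time of 48 h; a lower number here means that less compound is tolerated, a higher number that more compound is tolerated
Compound 2, `C=C1CC[C@@H]2[C@](C)(COC(C)=O)[C@H](OC(C)=O)CC[C@@]2(C)[C@H]1CC(Nc1ccc(S(=O)(=O)Nc2ncccn2)cc1)C1=CCOC1=O`, 6510 nM in this assay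

Compound 1 gives the highest of the two numbers, yet its nearest neighbour is compound 2, and a 1.2-fold lower number from compound 1 to compound 2 (0.09 log units; within the scatter) lies within the scatter. Compound 3, `C=C1CC[C@@H]2[C@](C)(COC(C)=O)[C@H](OC(C)=O)CC[C@@]2(C)[C@H]1CC(Nc1ccc(S(=O)(=O)Nc2cc(C)on2)cc1)C1=CCOC1=O`, is not yet measured; it differs from compound 1 by 5-methyl-1,2-oxazol-3-yl in place of 1,3-thiazol-2-yl on a sulfonamide nitrogen. Going by the values given here, the only measured step that bears on this, a 1.2-fold lower number from compound 1 to compound 2 (0.09 log units; within the scatter), also swapped the heteroaryl on that sulfonamide nitrogen and changed little. Compound 3 is therefore expected to show a 1.1-fold lower number from compound 1 to compound 3 (0.03 log units; within the scatter), no step beyond the scatter. The estimate for compound 3 is 7500 nM, with a range from 3500 nM to 16000 nM.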

Compound 3, concentration lethal to 50% of the cells: 5100 nM
Beside the measured number, compound 3's estimate is 1.5-fold (0.17 log units) above it; measured number inside the range.
By their numbers in this assay, from the lowest: compounds 3, 2 and 1 (each within the scatter of the next).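

In this assay, a third heteroaryl on the sulfonamide nitrogen still gives no separable change: a 1.6-fold lower number from compound 1 to compound 3 (0.20 log units; within the scatter), and a 1.3-fold lower number from compound 2 to compound 3 (0.11 log units; within the scatter). The series now spans 1,3-thiazol-2-yl, pyrimidin-2-yl and 5-methyl-1,2-oxazol-3-yl, including a ring that carries a methyl group, and all three remain within the scatter of one another. Nothing available explains this insensitivity. The compounds shown leave open whether a phenyl ring, an ethyl chain or a carboxylic acid on that nitrogen would also leave the number within the scatter.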